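Chloro for amino on the ring carbon of compound 3

The compounds below may be only part of what the source reports. "The series", "measured", "known", "first", "only" and "open" are said of these compounds alone.

Compound 3 `Nc1nccc2c1ncn2[C@H]1C[C@H](O)[C@@H](CO)O1` gives 18% in a functional assay (Homo sapiens) for inhibition of Nucleic Acid, tested at 100 uM (on this read-out lower numbers stand for less inhibition and higher numbers for more inhibition at the one concentration tested (going by the name of the read-out)), the highest of the three numbers, though the gap to compound 1 lies within the scatter. Compound 1 `OC[C@H]1O[C@@H](n2cnc3c(NCc4ccccc4)nccc32)C[C@@H]1O` gives 15%, and compound 2 `CCNc1nccc2c1ncn2C1O[C@H](CO)[C@@H](O)[C@H]1O` gives 4%, which leaves compound 2 beyond the scatter below compound 3. Compound 4 `OC[C@H]1O[C@@H](n2cnc3c(Cl)nccc32)C[C@@H]1O` has not been measured. It differs from compound 3 by chloro in place of amino on an aromatic carbon.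

Among the measured compounds shown here, the only measured single-point step concerns the same amino nitrogen: hydrogen in place of benzyl on it gave a number 3 percentage points higher from compound 1 to compound 3 (within the scatter), a change that did not move the read-out beyond the scatter. For the measured compounds named here, no measured step exchanges that nitrogen for another atom, so the size of the present change is not covered by the data. Going by the values given here, all three numbers sit in the low part of the scale, and the one relevant step shows that altering the substituent on this nitrogen made little difference, so no step beyond the scatter is expected from compound 3 to compound 4, estimated as a number 8 percentage points lower from compound 3 to compound 4 (within the scatter). Compound 4 is therefore expected to give about 10%, within the range -5% to 28%.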

Compound 4, a percentage reported as inhibition, at one concentration (the size of the read-out at that concentration, not a potency): 5%
Compound 4: middle estimate off by 5 percentage points, on the high side, within the range that was stated.
By their numbers in this assay, from the lowest: compounds 2, 4, 1 and 3 (each within the scatter of the next, the first and the last beyond it).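

In this assay, among the compounds shown here, exchanging the amino group itself on this aromatic carbon moves the read-out where a change on its nitrogen did not: chloro in place of amino gives a number 13 percentage points lower from compound 3 to compound 4 (beyond the scatter) and this is the only step at this position beyond the scatter, while hydrogen in place of benzyl gave a number 3 percentage points higher from compound 1 to compound 3 (within the scatter) and stayed within it. Starting from the benzylamino group, chloro gives a number 10 percentage points lower from compound 1 to compound 4 (within the scatter) and this stays within the scatter, so the exchange for chloro clears the scatter from one of the two starting points only. The three compounds therefore show a separation between amino and chloro on this carbon but none between benzylamino and either of them, and nothing measured on these compounds gives a reason for that separation.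

Still open, from the compounds shown here alone, is whether the lower number follows from losing the amino group or from the arrival of chloro in particular, which plain hydrogen, fluoro, methoxy or methyl on this aromatic carbon would help to separate. Also open, going by these compounds, is how a methyl or a longer chain such as butyl on the amino nitrogen would compare with amino and benzylamino on the shared core.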